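Sulfonyl aryl variation: compound 3 to compound 4

The source may hold more compounds than are shown below. What is called first, only, known or untested is meant among the compounds shown, and "the series" means these compounds.

Measured so far:
compound 1 `COc1ccc2ncc(S(=O)(=O)c3ccc(Cl)cc3)c(N3CCC(C)CC3)c2c1` gives 91%
compound 2 `COc1ccc(S(=O)(=O)c2cnc3ccc(OC)cc3c2N2CCC(C)CC2)cc1` gives 41%
compound 3 `COc1cccc(S(=O)(=O)c2cnc3ccc(OC)cc3c2N2CCC(C)CC2)c1` gives 0%

The read-out throughout is an assay on isolated protein for displacement of a labelled ligand from metabotropic glutamate receptor 5 (Homo sapiens), with a stated time of 60 min, tested at 1 uM; on this read-out higher numbers stand for more inhibition at the one concentration tested (going by the name of the read-out) and lower numbers for less inhibition. On the numbers shown, compound 3 stands lowest of the three; its nearest neighbour is compound 2, the furthest compound 1, both beyond the scatter.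

The step now followed is 3,5-dimethylphenyl in place of 3-methoxyphenyl on a sulfonyl sulfur, giving compound 4 `COc1ccc2ncc(S(=O)(=O)c3cc(C)cc(C)c3)c(N3CCC(C)CC3)c2c1`.

Within the data shown here, two measured steps touch the same sulfonyl aryl group. Replacing 4-chlorophenyl with 3-methoxyphenyl gave a number 91 percentage points lower from compound 1 to compound 3 (beyond the scatter). Replacing 4-methoxyphenyl with 3-methoxyphenyl gave a number 41 percentage points lower from compound 2 to compound 3 (beyond the scatter). The remaining step, methoxy for chloro, gave a number 50 percentage points lower from compound 1 to compound 2 (beyond the scatter). Among the measured compounds shown here, no measured step places a 3,5-dimethylphenyl, or any dimethyl aryl, on this sulfur, so the size of the change from compound 3 is not covered directly. What the three numbers show is that every aryl group tested so far other than 3-methoxyphenyl gave a higher read-out in this assay. A gain from the floor of compound 3 is therefore expected, but of uncertain size, since the entering group shares nothing measured here. The expected step is a number 30 percentage points higher from compound 3 to compound 4 (beyond the scatter). Compound 4 is estimated at 30%, within 0% to 70%.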

Compound 4, a percentage reported as inhibition, at one concentration (the size of the read-out at that concentration, not a potency): 79%
Estimate against measurement, compound 4: 49 percentage points below, outside the stated range (above it).
By their numbers in this assay, from the lowest: compound 3; then compound 2; then compound 4; then compound 1.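

In this assay, the sulfonyl sulfur position does not reject a 3-substituted phenyl group as such: a number 79 percentage points higher from compound 3 to compound 4 (beyond the scatter), although the two groups are alike in heavy-atom count and the entering 3,5-dimethylphenyl differs in replacing the oxygen of 3-methoxyphenyl with carbon and carrying no hydrogen-bond acceptor. The 4-substituted aryl groups therefore no longer mark the only route to a high read-out, since 3,5-dimethylphenyl in place of 4-methoxyphenyl gives a number 38 percentage points higher from compound 2 to compound 4 (beyond the scatter), while 4-chlorophenyl remains ahead, with a number 12 percentage points lower from compound 1 to compound 4 (beyond the scatter), a modest step beyond the scatter. The data shown offer no measured basis for explaining any of these steps.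

Open, from the compounds shown here alone, is whether the low read-out of compound 3 belongs to the methoxy group itself, which a single-substituent comparison with 3-methylphenyl or 3-chlorophenyl would separate from the effect of carrying a second methyl group. Also open, going by these compounds, is how this position responds to a 3,5-dichlorophenyl group or to a phenyl ring bearing an amine or a carboxylic acid, and whether the order seen at one concentration would hold in full concentration-response measurements.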